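The source may report more compounds than this note shows. Statements on the series, on what has been measured and on what is new or still open speak of the compounds shown alone.

Measured in a functional assay on MCF7 cells (Homo sapiens) for cytotoxicity, read by MTT assay, with a stated time of 72 h; on this read-out higher numbers stand for weaker inhibition and lower numbers for stronger inhibition:
- Compound 1 `O=C(Nc1ccc(Oc2ncnc3[nH]ccc23)c(F)c1)c1cc2cccnc2n(-c2ccc(F)cc2)c1=O`: 9230 nM
- Compound 2 `O=C(Nc1ccc(Oc2ncnc3[nH]ccc23)c(F)c1)c1cc2cccnc2n(-c2ccc(Br)cc2)c1=O`: 27000 nM

Of these two compounds, compound 2 has the higher number, so it is the weaker inhibitor in this assay, and compound 1 is its nearest neighbour. The next compound, compound 3 `O=C(Nc1ccc(Oc2ncnc3[nH]ccc23)c(F)c1)c1cc2cccnc2n(-c2ccc(Br)cc2F)c1=O`, keeps everything in compound 2 and adds one atom: fluoro in place of hydrogen on an aromatic carbon. In words, this is fluoro in place of hydrogen on an aromatic carbon, turning 4-bromophenyl into 4-bromo-2-fluorophenyl. The bromo group stays in place.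

Among the measured compounds shown here, only one measured step bears on this change: a 2.9-fold higher number from compound 1 to compound 2 (0.47 log units; beyond the scatter). It is modest, and it exchanges one halogen for another rather than adding fluoro to a ring that already carries bromo, so it offers only indirect guidance. For the measured compounds named here, no measured compound shows this addition directly. A large shift is therefore not expected, and the direction remains uncertain, with a slight lean towards a lower number. The expected change is a 1.4-fold lower number from compound 2 to compound 3 (0.13 log units; within the scatter), which would not clearly exceed the scatter. For compound 3 the estimate is 20000 nM, with an expected range of 8000 nM to 50000 nM.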

Compound 3, half-maximal inhibitory concentration: 102000 nM
Beside the measured number, compound 3's estimate is 5.1-fold (0.71 log units) below it; measured number above the stated range.
By their numbers in this assay, from the lowest: compound 1; then compound 2; then compound 3.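

In this assay, the added fluoro, ortho to a large group and meta to a bromo group, gives a 3.8-fold higher number from compound 2 to compound 3 (0.58 log units; beyond the scatter), so this ring position responds to a single added fluorine, with weaker inhibition, and not only to the exchange of one halogen for another that the earlier pair showed. Both single changes on this ring now point the same way, and together they separate the compounds by an 11-fold higher number from compound 1 to compound 3 (1.04 log units; beyond the scatter), which makes compound 3, with its 4-bromo-2-fluorophenyl group, the weakest of the three and compound 1, with its 4-fluorophenyl group, the strongest. Nothing available explains why a single fluorine in this place shifts the number in this cytotoxicity read-out.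

The compounds shown leave open whether this shift is specific to fluoro or would also follow from a methyl group, a methoxy group or an amine in the same place. They also leave open whether the same added fluoro would shift the number as much on the 4-fluorophenyl ring of compound 1, where no bromo group is present.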